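From 3,5-dimethoxyphenyl to 3-chlorophenyl on a shared core

The source may hold more compounds than are shown below. What is called first, only, known or untested is meant among the compounds shown, and "the series" means these compounds.

- compound 1 `COc1ccc(Cn2cnc3c(Nc4cccc(Cl)c4)nc(N[C@H]4CC[C@H](N)CC4)nc32)cc1` gives 530 nM here
- compound 2 `COc1cc(Nc2nc(N[C@H]3CC[C@H](N)CC3)nc3c2ncn3CCC(C)C)cc(OC)c1` gives 140 nM here

In a functional assay on EOL1 cells (Homo sapiens) for inhibition, read by fluorescence, with a stated time of 72 h (a lower number here means a stronger inhibitor of growth, a higher number a weaker inhibitor of growth), compound 2 has the lower of the two numbers, with 140 nM as its value, and the gap to compound 1 lies beyond the scatter. Compound 3 `CC(C)CCn1cnc2c(Nc3cccc(Cl)c3)nc(N[C@H]3CC[C@H](N)CC3)nc21` has not yet been measured. For the measured compounds named here, it differs from compound 2 by 3-chlorophenyl in place of 3,5-dimethoxyphenyl on a nitrogen on an aromatic ring and no measured pair shows this change alone. A modest rise in the number is expected, with the estimated step of a 1.8-fold higher number from compound 2 to compound 3 (0.25 log units; within the scatter) in this assay as a weaker inhibitor of growth. Compound 3 is estimated at 250 nM (from 80 nM to 700 nM).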

Compound 3, concentration for 50% growth inhibition: 60 nM
Beside the measured number, compound 3's estimate is 4.2-fold (0.62 log units) above it; the measured number lies below the stated range.
By their numbers in this assay, from the lowest: compound 3; then compound 2; then compound 1.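

With the chain held constant, 3-chlorophenyl in place of 3,5-dimethoxyphenyl on a nitrogen on an aromatic ring can now be read alone in this assay, giving a 2.3-fold lower number from compound 2 to compound 3 (0.37 log units; beyond the scatter) on this core. With 3-chlorophenyl held constant, isobutyl in place of 4-methoxyphenyl on a saturated chain carbon bound to an aromatic nitrogen gives an 8.8-fold lower number from compound 1 to compound 3 (0.95 log units; beyond the scatter) in the same assay. Nothing available here explains either step. Still open, from the compounds shown here alone, is how a single methoxy group or a fluorine on that phenyl ring would read, and how a longer chain or a chain ending in an amine would compare with isobutyl.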